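Swapping the urea end group toward a cyclohexylmethyl urea

The source may report more compounds than this note shows. Statements on the series, on what has been measured and on what is new or still open speak of the compounds shown alone.

Compound 1 `COc1cc(NC(C)CCCNC(=O)NCc2ccccc2)c2ncccc2c1` and compound 2 `CCN(CC)C(=O)NCCCC(C)Nc1cc(OC)cc2cccnc12` share a core and differ only at the urea end. In an ADME assay on WI-38 cells (Homo sapiens), read by MTT assay, with a stated time of 72 h (a higher number here means a weaker inhibitor, a lower number a stronger inhibitor), compound 1 gives 35000 nM. For compound 2 the result in this assay is a limit of the assay, > 100000 nM. Compound 2 therefore stands at the weak end of what has been measured, and the step of an at least 2.8-fold higher number from compound 1 to compound 2 (0.45 log units; beyond the scatter) rests on (the limit of > 100000 nM in this assay, at which 1 of the 2 values shown sits), so its full size is not known. Compound 3 `COc1cc(NC(C)CCCNC(=O)NCC2CCCCC2)c2ncccc2c1` carries (cyclohexylmethyl)amino in place of diethylamino on a carbonyl carbon. Like the benzylamino group of compound 1, the entering group is an amino group bearing a methylene-linked six-membered ring. Within the data shown here, the only measured step, an at least 2.8-fold higher number from compound 1 to compound 2 (0.45 log units; beyond the scatter), raised the number when benzylamino gave way to diethylamino, so moving back toward a ring-bearing group is expected to lower it again. Compound 3 is expected to give 40000 nM in this assay, with a range from 15000 nM to 100000 nM. This amounts to an expected step of an at least 2.5-fold lower number from compound 2 to compound 3 (0.39 log units; beyond the scatter).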

Compound 3, half-maximal inhibitory concentration: > 100000 nM
Compound 3 gave a limit, no number; the forecaster's own chance of this, stated with the estimate: 25%; middle value at least 2.5-fold (0.39 log units) away from the limit.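

Changing the ring from aromatic to saturated is enough to shift the reading: in this assay, cyclohexyl in place of phenyl on a saturated chain carbon bound to an amide-type nitrogen gives an at least 2.8-fold higher number from compound 1 to compound 3 (0.45 log units; beyond the scatter). A methylene-linked six-membered ring alone therefore does not bring the number back toward that of compound 1, and among these three compounds only compound 1, with its phenyl ring, gives a number rather than a limit. On these data alone, the full size of this step stays unknown, and the step between compound 2 and compound 3 cannot be read at all, because these values are limits: the limit of > 100000 nM in this assay, at which 2 of the 3 values shown sit.

Still open, as far as these compounds go, is whether the phenyl ring itself matters or also its distance from the urea. How a phenylamino or a 2-phenylethylamino group on this carbonyl carbon would read in this assay remains an open question.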